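Working notes: amide-to-carbamate change at the pyrazole-type position

The source may report more compounds than this note shows. Statements on the series, on what has been measured and on what is new or still open speak of the compounds shown alone.

Measured compounds:
compound 1 `CNC(=O)c1cc(C)n(Cc2cc(Cl)ccc2OCc2ccccc2)n1` — > 3.7
compound 2 `Cc1cc(C(=O)Nc2ccc(F)cc2)nn1Cc1cc(Cl)ccc1OCc1ccccc1` — 3
compound 3 `Cc1cc(NC(=O)C(C)C)nn1Cc1cc(Cl)ccc1OCc1ccccc1` — > 3.7

In a physicochemical assay for lipophilicity, at pH 7.4 (on this read-out lower numbers stand for lower lipophilicity and higher numbers for higher lipophilicity), compound 1 gives > 3.7, which is a limit of the assay and not a number. Compound 2 gives 3 in this assay, a measured number. Compound 3 gives > 3.7, again only a limit. Two of the three values therefore sit at the same limit (the limit of > 3.7 in this assay, at which 2 of the 3 values shown sit), so compound 1 stands at the upper edge of what this assay reports, with no number of its own.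

Compound 4 `Cc1cc(NC(=O)OCC(C)C)nn1Cc1cc(Cl)ccc1OCc1ccccc1` is not yet measured. It differs from compound 1 in one place: (isobutoxycarbonyl)amino in place of methylcarbamoyl on an aromatic carbon.

The measured steps that bear on this change are a step that the two limits leave unreadable from compound 1 to compound 3, the same kind of exchange at the same aromatic carbon, and a number at least 0.70 log units higher from compound 2 to compound 3 (beyond the scatter). The first is not readable in size, the second is at least modest and upward. Nothing points to compound 4 falling below the limit at which compound 1 sits.

Compound 4 is therefore expected at 4.5, between 3.8 and 5.3, most likely reported as a limit only. The step that the limit leaves unreadable from compound 1 to compound 4 is an estimate, upward or flat, not a measured value.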

Compound 4, distribution coefficient: 3.3
Compound 4: the middle estimate sits 1.20 log units above what was measured; measured number outside the range, below it.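

In this assay, among the compounds shown here, the single exchange at this aromatic carbon gives a number at least 0.40 log units lower from compound 1 to compound 4 (beyond the scatter), so a measured number is reached here without the 4-fluorophenyl group of compound 2. The change on the carbonyl carbon alone, isobutoxy in place of isopropyl, gives a number at least 0.40 log units lower from compound 3 to compound 4 (beyond the scatter), so the outcome at this position depends on the group on that carbonyl carbon and not only on the reversed amide-type link shared by compound 3 and compound 4. The exchange against the anilide-type side chain gives a number 0.30 log units higher from compound 2 to compound 4 (within the scatter), so this assay does not separate these two groups at this aromatic carbon.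

Going by these compounds, the step between compound 1 and compound 3 cannot be read, and the two downward steps have a lower bound on their size but no full size, as their starting values are limits and not numbers: the limit of > 3.7 in this assay, at which 2 of the 4 values shown sit. Whether a longer chain in place of isobutoxy, or an amine or a carboxylic acid on the same carbonyl carbon, would keep the value in the measurable range stays open.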